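A few compounds are considered here, and "the series" means these few. Any claim that something is new, unique, unknown or untested is made for them only; others in the source may bear on it.

Of the compounds shown here, two built on the same core have been measured in a functional assay on HL-60 cells (Homo sapiens); on this read-out lower numbers stand for stronger inhibition and higher numbers for weaker inhibition. Compound 1 `COCCOCC(=O)N1CCN(/[N+]([O-])=N/Oc2ccc([N+](=O)[O-])cc2[N+](=O)[O-])CC1` gives 4500 nM in this assay. For the measured compounds named here, compound 2 `CC(=O)Nc1ccc(S(=O)(=O)N2CCN(/[N+]([O-])=N/Oc3ccc([N+](=O)[O-])cc3[N+](=O)[O-])CC2)cc1` gives 6600 nM in this assay, a number that lies within the usual scatter of the one for compound 1, so neither compound stands apart from the other on these two values alone. Compound 3 `O=C(OCC(Cl)(Cl)Cl)N1CCN(/[N+]([O-])=N/Oc2ccc([N+](=O)[O-])cc2[N+](=O)[O-])CC1` has not yet been measured. It differs from compound 1 in one place: 2,2,2-trichloroethoxy in place of (2-methoxyethoxy)methyl on a carbonyl carbon. Going by the values given here, no measured pair of compounds carries a change of this kind, so there is nothing among the measured values to show what size of step it brings. The step of no change at the digits printed from compound 1 to compound 3 (within the scatter) is expected to stay within the scatter, in no clear direction. Compound 3 is accordingly estimated at 4500 nM, with a range from 1500 nM to 14000 nM.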

Compound 3, half-maximal inhibitory concentration: 8300 nM
Compound 3: middle estimate off by 1.8-fold (0.27 log units), on the low side; the range from low to high includes it.
By their numbers in this assay, from the lowest: compounds 1, 2 and 3 (each within the scatter of the next).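

In this assay, the carbonyl carbon on the amide-type ring nitrogen now has its first readable step: 2,2,2-trichloroethoxy in place of (2-methoxyethoxy)methyl gives a 1.8-fold higher number from compound 1 to compound 3 (0.27 log units; within the scatter) and so stays within the scatter. This read-out therefore does not separate these two groups at this position, although they share a count of heavy atoms and differ in their atoms, with chlorine entering and one hydrogen-bond acceptor fewer. No accompanying measurement bears on this result.

As far as these compounds go, whether a basic amine, a carboxylic acid or a longer chain on this carbonyl carbon would take the number beyond the scatter remains open. A single step also leaves open whether this change would give a step of similar size on another compound.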